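This account rests on a few compounds, and the source may have more. Where it says the series, first, only, none or still open, it means among the compounds named here.

Measured so far in a functional assay on HL-60 cells (Homo sapiens) for cytotoxicity, read by luminescence and CellTiter-Glo, with a stated time of 3 days; a lower number here means a stronger inhibitor, a higher number a weaker inhibitor:
- compound 1 `O=C(Nc1ccc(C(F)(F)F)cc1)c1cc(Cl)ccc1O`: 510 nM
- compound 2 `N#Cc1cccc(NC(=O)c2cc(F)ccc2O)c1`: 7750 nM
- compound 3 `O=C(Nc1ccc(C(F)(F)F)cc1)c1cc(Cl)c(-c2ccccc2)cc1O`: 490 nM

Compound 3, at 490 nM, is level with compound 1 within the scatter. Compound 2, at 7750 nM, has a clearly higher number than compound 3, so compound 3 belongs with the lower end of this small set.

The next compound is compound 4 `O=C(Nc1ccc(C(F)(F)F)cc1)c1cc(Br)c(-c2ccccc2)cc1O`. The change from compound 3 is bromo in place of chloro on an aromatic carbon, ortho to a phenyl group and para to a hydroxy group.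

Going by the values given here, no measured step covers this exchange. Among the compounds with values here, the only step available is a 1.0-fold lower number from compound 1 to compound 3 (0.02 log units; within the scatter), and it concerns phenyl in place of hydrogen on an aromatic carbon. It bears on the new change only indirectly, as a substitution on the same ring that left the number within the scatter. Compound 2 differs from the others in more than one place and gives no clean reading on the halogen.

With so little to go on, no step beyond the scatter is expected in this assay, and the estimate amounts to a 1.1-fold lower number from compound 3 to compound 4 (0.04 log units; within the scatter). For compound 4 the expected value is 450 nM, with an estimated range from 220 nM to 950 nM.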

Compound 4, half-maximal inhibitory concentration: 540 nM
Compound 4: the middle estimate sits 1.2-fold (0.08 log units) below what was measured; the range from low to high includes it.
By their numbers in this assay, from the lowest: compounds 3, 1 and 4 (each within the scatter of the next); then compound 2.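

In this assay, the exchange of chloro for bromo gives a 1.1-fold higher number from compound 3 to compound 4 (0.04 log units; within the scatter), so on this carbon, ortho to a phenyl group and para to a hydroxy group, the two halogens cannot be told apart by this read-out. The earlier step, a 1.0-fold lower number from compound 1 to compound 3 (0.02 log units; within the scatter), covered only the arrival of the phenyl group and left the halogen unchanged, whereas this pair varies the halogen itself with the phenyl group in place. The reading is limited to one halogen pair on this one background, and no measurement on the compounds explains why the exchange stays within the scatter.

Both halogens shown on this carbon are single heavy atoms with no hydrogen-bond donors or acceptors, so it remains open whether the level reading would hold for an amine, a carboxylic acid or a longer chain there. Also open, going by these compounds, is how far the number depends on the hydroxy group and the trifluoromethyl group, since compound 2 differs from the others in more than one place and gives no clean reading on either.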